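Compound 2 to compound 4: a larger group on the core

This account rests on a few compounds, and the source may have more. Where it says the series, first, only, none or still open, it means among the compounds named here.

In a physicochemical assay for permeability, using PAMPA (on this read-out lower numbers stand for lower permeability and higher numbers for higher permeability), compound 2 (`CC(C)Cc1cc2oc(=O)n(CCC(=O)O)c2cc1Cl`) reads < 10 nm/s and that is a limit, not a number. Among the compounds with values here, it is the only compound so far at that limit (the limit of < 10 nm/s in this assay, at which 1 of the 3 values shown sits). In this assay compound 3 (`O=C(O)CCn1c(=O)oc2cc(OCc3ccccn3)c(Cl)cc21`) gives 11 nm/s and compound 1 (`Cc1ccc([C@@H](C)Oc2cc3oc(=O)n(CCC(=O)O)c3cc2Cl)nc1`) gives 22 nm/s with a ring-bearing group at the same place.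

The change to compound 4 (`C[C@@H](Oc1cc2oc(=O)n(CCC(=O)O)c2cc1Cl)c1ncco1`) is a group of 8 heavy atoms (5 carbon, 1 nitrogen, 2 oxygen; one five-membered aromatic ring with 2 hetero atoms) in place of a group of 4 heavy atoms (4 carbon; no ring), on an aromatic carbon and it sits on an aromatic carbon, ortho to a chloro group. Within the data shown here, the one measured step that bears on it is an at least 1.1-fold higher number from compound 2 to compound 3 (0.04 log units; that floor lies within the scatter) and it also replaces isobutyl at that place. Its floor lies within the scatter, so it fixes direction only loosely.

With compound 3 at 11 nm/s and compound 1 at 22 nm/s as the guide, a modest rise is expected in this assay. For compound 4 a reading at the limit seen for compound 2 remains possible. The step expected is an at least 1.2-fold higher number from compound 2 to compound 4 (0.07 log units; that floor lies within the scatter) and it runs upward, small in size. For compound 4 the estimate is 12 nm/s (expected range 7 nm/s to 25 nm/s).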

Compound 4, apparent permeability: < 3 nm/s
Compound 4: only a limit was reported; the forecaster's own chance of this, stated with the estimate: 35%; at least 4.0-fold (0.60 log units) between middle value and limit.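

In this assay compound 4 gives < 3 nm/s, and that is a limit, not a number. With 1,3-oxazol-2-yl in place of 5-methylpyridin-2-yl on the saturated chain carbon, the read-out shows an at least 7.3-fold lower number from compound 1 to compound 4 (0.86 log units; beyond the scatter), and with the five-membered aromatic ring group in place of the six-membered one on the oxygen on an aromatic ring it shows an at least 3.6-fold lower number from compound 3 to compound 4 (0.56 log units; beyond the scatter). A ring-bearing group at this place therefore does not by itself hold the number up, as compounds 1 and 3 alone could have suggested: the identity of the ring counts, within these three compounds.

The step from compound 2 cannot be read, as both values are limits. Still open, going by these compounds, is how far the number moves with a phenyl group or a 1,3-thiazol-2-yl group on the same chain carbon.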